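Ring-nitrogen 4-methylphenyl on a chloropyridine sulfonamide

The source may report more compounds than this note shows. Statements on the series, on what has been measured and on what is new or still open speak of the compounds shown alone.

Four compounds share one core. Compound 2 `COc1ncc(-c2ccc3c(c2)NC(=O)CO3)cc1NS(=O)(=O)c1ccc(F)cc1` gives 24900 nM in a functional assay on HCT-116 cells (Homo sapiens) for antiproliferative activity, read by MTT assay, with a stated time of 72 h; on this read-out lower numbers stand for stronger inhibition and higher numbers for weaker inhibition. Compound 1 `COc1ncc(-c2ccc3c(c2)N(c2ccc(C)cc2)C(=O)CO3)cc1NS(=O)(=O)c1ccc(F)cc1` carries a 4-methylphenyl in place of hydrogen on an amide-type nitrogen in a ring and gives 22700 nM in this assay; this change 4-methylphenyl in place of hydrogen on an amide-type nitrogen in a ring produced a 1.1-fold lower number from compound 2 to compound 1 (0.04 log units; within the scatter). Compound 3 `O=C1COc2ccc(-c3cnc(Cl)c(NS(=O)(=O)c4ccc(F)cc4)c3)cc2N1` differs from compound 2 in its core by a chloro in place of methoxy on an aromatic carbon, a step of an at least 1.6-fold higher number from compound 2 to compound 3 (0.20 log units; that floor lies within the scatter). In this assay compound 3 reaches only a limit, > 40000 nM, as noted in the limit of > 40000 nM in this assay, at which 1 of the 3 values shown sits. Compound 4 `Cc1ccc(N2C(=O)COc3ccc(-c4cnc(Cl)c(NS(=O)(=O)c5ccc(F)cc5)c4)cc32)cc1` is compound 3 with the same change, 4-methylphenyl in place of hydrogen on an amide-type nitrogen in a ring. Since that change left compound 1 and compound 2 within the scatter, the step of a number no higher from compound 3 to compound 4 (the limit leaves the size open) is expected to be small. Compound 4 is therefore estimated at 40000 nM, between 20000 nM and 80000 nM.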

Compound 4, half-maximal inhibitory concentration: 34300 nM
Estimate against measurement, compound 4: 1.2-fold (0.07 log units) above; low and high end bracket the measured number.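

In this assay compound 3 reaches only a limit, > 40000 nM. The 4-methylphenyl in place of hydrogen on the amide-type nitrogen in a ring gives an at least 1.1-fold lower number from compound 3 to compound 4 (0.06 log units; that floor lies within the scatter), so nothing beyond the scatter is shown on either core, yet a true match between the two cores is not shown either: the same change on two cores in this assay, a 1.1-fold lower number (0.04 log units; within the scatter) from compound 2 to compound 1 and an at least 1.1-fold lower number (0.06 log units; that floor lies within the scatter) from compound 3 to compound 4; the limit leaves it open whether they differ The chloro in place of methoxy likewise stays without a step shown beyond the scatter, with a 1.5-fold higher number from compound 1 to compound 4 (0.18 log units; within the scatter), and the same reservation holds: the same change on two cores in this assay, an at least 1.6-fold higher number (0.20 log units; that floor lies within the scatter) from compound 2 to compound 3 and a 1.5-fold higher number (0.18 log units; within the scatter) from compound 1 to compound 4; the limit leaves it open whether they differ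

The compounds shown leave open how an amine, a carboxylic acid or a longer chain would behave on that amide-type nitrogen in place of the 4-methylphenyl. They also leave open whether any such group would carry from one core to the other.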